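From Hydroxy to Fluoro at the Edge of the Assay

This account rests on a few compounds, and the source may have more. Where it says the series, first, only, none or still open, it means among the compounds named here.

Compound 1 `CC(C)Oc1cc(-c2ccccc2)nc2ccccc12` and compound 2 `CCCOc1cc(-c2ccccc2)nc2ccccc12` differ only in the group on an oxygen, isopropyl in one and propyl in the other. In a functional assay on P388 cells (Mus musculus) for cytotoxicity (a higher number here means that more compound is needed for the effect, a lower number that less compound is needed), compound 1 gives only a limit, > 10 ug/mL. Compound 2 gives a real number, 6.9 ug/mL. The one measured step between a pair of these compounds is an at least 1.4-fold lower number from compound 1 to compound 2 (0.16 log units; that floor lies within the scatter).

Compound 3 `Oc1cc(-c2ccccc2)nc2c(O)cccc12` also gives only a limit, > 10 ug/mL. Its standing is therefore not a number, and it shares the most common result in this small set: the limit of > 10 ug/mL in this assay, at which 2 of the 3 values shown sit.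

Compound 4 `Oc1cc(-c2ccccc2)nc2c(F)cccc12` changes one group of compound 3: fluoro in place of hydroxy on an aromatic carbon. Among the measured compounds shown here, no measured step covers this swap of hydroxy for fluoro. For the measured compounds named here, the only measured step, an at least 1.4-fold lower number from compound 1 to compound 2 (0.16 log units; that floor lies within the scatter), involves other groups and has a floor within the scatter, so it gives no reason to expect a change of any size or direction in this assay. The working expectation is therefore no step beyond the scatter, although a limit could conceal one.

The estimated step is a step that the limit leaves unreadable from compound 3 to compound 4. For compound 4 the expected value is 11 ug/mL, with an estimated range from 4 ug/mL to 30 ug/mL.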

Compound 4, half-maximal effective concentration: 0.67 ug/mL
For compound 4 the middle estimate is 16-fold (1.22 log units) above the measured one, outside the stated range (below it).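

Fluoro in place of hydroxy on an aromatic carbon, ortho to a fused ring and meta to a fused ring, gives in this assay an at least 14-fold lower number from compound 3 to compound 4 (1.17 log units; beyond the scatter). This is the first step among these compounds that lies beyond the scatter, so a single-atom swap at this place on the shared core can move the result far, and it does so while the other hydroxy of compound 3 stays in place. The printed size is only a floor, and the real step may be larger, because compound 3 stands at a limit and not at a number: the limit of > 10 ug/mL in this assay, at which 2 of the 4 values shown sit.

The swap takes away a group counted as one hydrogen-bond donor and one acceptor and brings in a group counted as neither, but this single pair cannot tell whether the lower number comes from losing hydroxy or from gaining fluoro. Chloro, methoxy or an amine at the same place would help separate those two readings, and a propyl group on the remaining oxygen would test whether the effect of fluoro carries over to the ethers of compound 1 and compound 2.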